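The compounds below may be only part of what the source reports. "The series", "measured", "known", "first", "only" and "open" are said of these compounds alone.

A solubility reading says how much of a compound stays in solution under fixed conditions. In a physicochemical assay for solubility, read by nephelometry, in phosphate buffer, measured as kinetic solubility, at pH 6.5 (on this read-out higher numbers stand for higher solubility and lower numbers for lower solubility), compound 1 `CCOC(=O)C1=C(O)/C(=C\c2cc(C)n(-c3ccc(F)cc3)c2C)N=C1C` gives 3.1 ug/mL and compound 2 `CCOC(=O)C1=C(C)N/C(=C/c2cc(C)n(-c3ccc(Cl)cc3)c2C)C1=O` gives 1.6 ug/mL in the same test. These two values lie within the usual scatter of repeated measurements, so compound 2 cannot be told apart from compound 1 on these numbers.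

Compound 3 `CCOC(=O)C1=C(C)N/C(=C/c2cc(C)n(-c3ccc(N(C)C)cc3)c2C)C1=O` keeps the structure of compound 2 with one change, dimethylamino in place of chloro on an aromatic carbon and the same difference, cut one bond further out, reads 4-chlorophenyl to 4-(dimethylamino)phenyl.

Within the data shown here, no measured pair of compounds differs in one place only, so there is no direct precedent for this change, and any forecast is uncertain. The expectation is a slight upward lean and nothing clearly beyond the scatter in this assay for this swap. The estimated step is a 1.9-fold higher number from compound 2 to compound 3 (0.27 log units; within the scatter) and it should be read as a small one. Compound 3 is estimated at 3 ug/mL (range 1 ug/mL to 9 ug/mL).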

Compound 3, solubility: < 1.6 ug/mL
Compound 3 gave a limit, no number; the forecaster's own chance of this, stated with the estimate: 10%; middle value at least 1.8-fold (0.27 log units) from the limit.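

In this assay, among these compounds, this is the first direct look at a single change on this ring, and dimethylamino in place of chloro on an aromatic carbon gives a number no higher from compound 2 to compound 3 (the limit leaves the size open), which fixes a direction while the size of the step cannot be read. Compound 3 gives < 1.6 ug/mL, which is a limit of the assay and not a number. For a newcomer, the practical lesson is that at this place, para to a large group, swapping 4-chlorophenyl for 4-(dimethylamino)phenyl brought no gain in the reading, and the result marks the floor of what the test can report: the limit of < 1.6 ug/mL in this assay, at which 1 of the 3 values shown sits.

The compounds shown leave open how large this step really is, since a reading with a measurable number on both sides would be needed to size it. They also leave open whether a different kind of group on the same aromatic carbon, such as a carboxylic acid or a morpholine ring, would give a number clearly beyond the scatter of the test.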